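This account rests on a few compounds, and the source may have more. Where it says the series, first, only, none or still open, it means among the compounds named here.

Measured compounds:
Compound 1, `COc1ccc(CNC(=O)/C=C/c2coc3cc(O)ccc3c2=O)cc1`, gives > 200000 nM in a functional assay on L02 cells (Homo sapiens) for inhibition, read by MTT assay, with a stated time of 48 h (on this read-out lower numbers stand for stronger inhibition and higher numbers for weaker inhibition), a limit of the assay rather than a number.
Compound 2, `O=C(/C=C/c1coc2cc(O)ccc2c1=O)NCc1ccccc1`, gives > 200000 nM in this assay, again a limit.
Compound 3, `COc1ccc2c(=O)c(/C=C/C(=O)NCc3ccccc3)coc2c1`, gives > 200000 nM in this assay, again a limit.

Compound 3 therefore stands at the limit that all three measured compounds share, as the limit of > 200000 nM in this assay, at which 3 of the 3 values shown sit, records. Compound 4, `COc1ccc2c(=O)c(/C=C/C(=O)Nc3cc(C)ccc3C)coc2c1`, differs from compound 3 by 2,5-dimethylphenyl in place of benzyl on an amide-type nitrogen. Two measured steps exist within the set: the step that the two limits leave unreadable from compound 1 to compound 2 and the step that the two limits leave unreadable from compound 2 to compound 3. Neither of them can be read in size, since every value involved is a limit, and neither touches the amide-type nitrogen that changes here. Among the measured compounds shown here, no measured step therefore bears on the change from compound 3 to compound 4 in a readable way. With all three measured compounds sitting at the same limit, compound 4 is expected to stay in the same region of this assay, and the step that the limit leaves unreadable from compound 3 to compound 4 is expected to be small or not readable. For compound 4 the estimate in this assay is 250000 nM, in the range 80000 nM to 600000 nM, with a strong chance that only a limit is reported.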

Compound 4, half-maximal inhibitory concentration: > 200000 nM
Compound 4: only a limit was reported (the forecaster's own chance of this, stated with the estimate: 80%); the middle value lies beyond the limit too.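

No size can be read for the change from compound 3 to compound 4, as both values in this assay are limits of the assay. The compounds shown leave open how far each lies beyond that shared limit, and whether any of these changes alters inhibition in this assay at all.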